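Replacing a hydroxamate chain by a phenyl hydroxamate on the urea

The source may report more compounds than this note shows. Statements on the series, on what has been measured and on what is new or still open speak of the compounds shown alone.

Three compounds sharing one core were measured in an assay on isolated protein for inhibition of E3 ubiquitin-protein ligase Mdm2 (Homo sapiens), read by fluorescence polarization, with a stated time of 30 min; a lower number here means a stronger inhibitor, a higher number a weaker inhibitor. Compound 1 `CCOc1cc(C(C)(C)C)ccc1C1=NC(c2ccc(Cl)cc2)C(c2ccc(Cl)cc2)N1C(=O)NCCCCCCCC(=O)NO` gives 340 nM. Compound 2 `CCOc1cc(C(C)(C)C)ccc1C1=NC(c2ccc(Cl)cc2)C(c2ccc(Cl)cc2)N1C(=O)N1CCN(Cc2ccc(C(=O)NO)cc2)CC1` gives 260 nM, and compound 3 `CCOc1cc(C(C)(C)C)ccc1C1=NC(c2ccc(Cl)cc2)C(c2ccc(Cl)cc2)N1C(=O)N1CCN(CCCCCCCC(=O)NO)CC1` gives 290 nM. Between compound 3 and compound 2 the change is 4-(hydroxycarbamoyl)phenyl in place of 6-(hydroxycarbamoyl)hexyl on a saturated chain carbon bound to an amine nitrogen in a ring and the step was a 1.1-fold lower number from compound 3 to compound 2 (0.05 log units; within the scatter). How the cores of compound 1 and compound 3 differ is not broken down here.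

Compound 4 `CCOc1cc(C(C)(C)C)ccc1C1=NC(c2ccc(Cl)cc2)C(c2ccc(Cl)cc2)N1C(=O)NCc1ccc(C(=O)NO)cc1` is not yet measured. From compound 1 it differs by 4-(hydroxycarbamoyl)phenyl in place of 6-(hydroxycarbamoyl)hexyl on a saturated chain carbon bound to an amide-type nitrogen, a change of the same kind as that from compound 3 to compound 2, though the place is a saturated chain carbon bound to an amide-type nitrogen rather than to an amine nitrogen in a ring. Resting on compound 1 at 340 nM and the earlier step of a 1.1-fold lower number from compound 3 to compound 2 (0.05 log units; within the scatter), the expected step is a 1.1-fold lower number from compound 1 to compound 4 (0.05 log units; within the scatter). For compound 4 the estimate in this assay is 300 nM, between 150 nM and 600 nM.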

Compound 4, inhibition constant: 580 nM
Compound 4: the middle estimate sits 1.9-fold (0.29 log units) below what was measured, and the stated range covers the measured number.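

In this assay, putting 4-(hydroxycarbamoyl)phenyl in place of 6-(hydroxycarbamoyl)hexyl gives a 1.7-fold higher number from compound 1 to compound 4 (0.23 log units; within the scatter), so the change stays within the scatter here, as it did on the other core. The two steps cannot be told apart: the same change on two cores in this assay, a 1.1-fold lower number (0.05 log units; within the scatter) from compound 3 to compound 2 and a 1.7-fold higher number (0.23 log units; within the scatter) from compound 1 to compound 4, 1.9-fold (0.28 log units) apart, within the scatter of two such steps. This shows that, in these two pairs, the change carried from one core to the other without a difference that could be resolved, but it does not show that the change would behave the same way on any further core, nor does it exclude a small dependence on the core.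

On these data alone, it remains open whether a shorter or longer chain ending in the hydroxamic acid would fit the same picture. As far as these compounds go, the effect of a carboxylic acid in place of the hydroxamic acid also remains open.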